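Swapping 2,4,5-trifluorophenyl for 2,4,6-trifluorophenyl: an expected flat step

The source may hold more compounds than are shown below. What is called first, only, known or untested is meant among the compounds shown, and "the series" means these compounds.

Of the compounds shown here, two built on one shared core have been measured so far. In a functional assay with Homo sapiens as the target (a higher number here means a weaker inhibitor, a lower number a stronger inhibitor), compound 1 (`CC(C)[C@H](NC(=O)COc1cccc2ccccc12)C(=O)N[C@@H](CC(=O)O)C(=O)COc1ccc(F)cc1`) gives 14300 nM. In the same test compound 2 (`CC(C)[C@H](NC(=O)COc1cccc2ccccc12)C(=O)N[C@@H](CC(=O)O)C(=O)COc1cc(F)c(F)cc1F`) gives 16700 nM, a value that cannot be told apart from that of compound 1. The next compound to be tested is compound 3 (`CC(C)[C@H](NC(=O)COc1cccc2ccccc12)C(=O)N[C@@H](CC(=O)O)C(=O)COc1c(F)cc(F)cc1F`), which has the same atoms as compound 2, joined differently: 2,4,6-trifluorophenyl in place of 2,4,5-trifluorophenyl on an oxygen on a saturated carbon. Here 2,4,6-trifluorophenyl stands in place of 2,4,5-trifluorophenyl on an oxygen on a saturated carbon. Going by the values given here, only one measured step bears on this change, since it falls at the same place: a 1.2-fold higher number from compound 1 to compound 2 (0.07 log units; within the scatter). Adding to the ring at that place thus left the number within the scatter, but no measured compound yet carries the 2,4,6-trifluorophenyl group, so this guide is thin. No shift beyond the scatter is therefore expected in this assay, and the estimated step is a 1.1-fold lower number from compound 2 to compound 3 (0.05 log units; within the scatter). The expected value for compound 3 is 15000 nM, with an estimated range of 7000 nM to 32000 nM.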

Compound 3, half-maximal inhibitory concentration: 14900 nM
Beside the measured number, compound 3's estimate is 1.0-fold (0.00 log units) above it, within the range that was stated.
By their numbers in this assay, from the lowest: compounds 1, 3 and 2 (each within the scatter of the next).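

In this assay, rearranging the same three fluorine atoms, from the 2,4,5-trifluorophenyl group to the 2,4,6-trifluorophenyl group, gives a 1.1-fold lower number from compound 2 to compound 3 (0.05 log units; within the scatter), so at this place, on an oxygen on a saturated carbon, the arrangement of the fluorines leaves the number within the scatter for these two patterns. Set against the 4-fluorophenyl group, the 2,4,6-trifluorophenyl group gives a 1.0-fold higher number from compound 1 to compound 3 (0.02 log units; within the scatter), which means that both trifluorophenyl groups now stand within the scatter of the group carrying a single fluorine, and the three compounds cannot be ordered in this test. Nothing available on these compounds offers an explanation for this flat behaviour.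

Going by these compounds, all three compounds carry only fluorine on this ring, so it remains open whether a methoxy group, an amine or a carboxylic acid on the same ring, or a different group in place of the phenyl ring, would move the number beyond the scatter. The compounds shown also vary only this one place, which leaves open how the number responds to changes elsewhere on the shared core.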